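The source may hold more compounds than are shown below. What is called first, only, known or untested is meant among the compounds shown, and "the series" means these compounds.

This account concerns three measured compounds and one that is not yet measured, all tested in a functional assay on MDA-MB-231 cells (Homo sapiens) for cytotoxicity, read by sulforhodamine B assay, with a stated time of 48 h, tested at 0.1 uM; on this read-out higher numbers stand for a weaker effect at the one concentration tested and lower numbers for a stronger effect. Compound 1, with the structure `COc1cc(-c2cc(/C=C/C(=O)c3ccc(N)cc3)[nH]n2)cc(OC)c1OC`, gives 91% in this assay. Compound 2, with the structure `COc1ccc(-c2cc(/C=C/C(=O)c3ccc(N)cc3)[nH]n2)cc1OC`, gives 107% in this assay. The two differ by one change, (hydrogen in place of methoxy on an aromatic carbon), and the step is a number 16 percentage points higher from compound 1 to compound 2 (beyond the scatter).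

Compound 3, with the structure `COc1cc(C(=O)/C=C/c2cc(-c3cc(OC)c(OC)c(OC)c3)n[nH]2)cc(OC)c1OC`, gives 104% in this assay. The difference between the core of compound 3 and the core of compound 1 is not broken down here. Compound 4, with the structure `COc1ccc(-c2cc(/C=C/C(=O)c3cc(OC)c(OC)c(OC)c3)[nH]n2)cc1OC`, has not yet been measured in this assay. Compound 4 differs from compound 3 by hydrogen in place of methoxy on an aromatic carbon, and the place of this change is described in the same words as the place of the change from compound 1 to compound 2, so the two changes are the same.

Within the data shown here, because the only comparable step is a number 16 percentage points higher from compound 1 to compound 2 (beyond the scatter), the account expects the step from compound 3 to compound 4 to be of a similar or smaller size, about a number 3 percentage points higher from compound 3 to compound 4 (within the scatter), and this expectation rests on a single pair of compounds only. Since compound 3 already gives 104%, there is little room for a weaker effect to show on this read-out. Compound 4 is therefore estimated at 107% in this assay, with a range from 92% to 122%.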

Compound 4, a percentage reported as activity, at one concentration (the size of the read-out at that concentration, not a potency): 93%
Beside the measured number, compound 4's estimate is 14 percentage points above it; the measured number falls inside the stated range.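

In this assay the new step is a number 11 percentage points lower from compound 3 to compound 4 (beyond the scatter), which runs the opposite way to the step seen on the core of compound 1, and the two do not agree: the same change on two cores in this assay, a number 16 percentage points higher (beyond the scatter) from compound 1 to compound 2 and a number 11 percentage points lower (beyond the scatter) from compound 3 to compound 4, 27 percentage points apart, beyond the scatter of two such steps

This shows that, among the compounds shown, hydrogen in place of methoxy at this place cannot be carried from one core to another as a fixed step, either in size or in direction. It does not show which part of the cores decides the outcome, since compound 1 and compound 3 differ in more than one place, and two pairs tested at a single concentration give neither a potency nor a rule for any further core.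

The compounds shown leave open how a hydroxy group or a fluorine at the same place would behave on either core. Among these compounds, they also leave open whether a carboxylic acid or a nitrile in place of the amine of compound 1 and compound 2 would bring the step from that core closer to the one from compound 3.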